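A few compounds are considered here, and "the series" means these few. Any claim that something is new, unique, unknown or untested is made for them only; others in the source may bear on it.

Measured compounds:
compound 1, `COc1ccc(-c2nnc3nnc(N4CCCCC4)n3n2)cc1`: > 100000 nM
compound 2, `Clc1ccccc1-c1nnc2nnc(N3CCCC3)nn12`: 2990 nM
compound 3, `Fc1ccc(-c2nnc3nnc(N4CCCC4)n3n2)cc1`: > 100000 nM

In a functional assay on BeWo cells (Homo sapiens) for cytotoxicity, read by MTT assay, with a stated time of 72 h (on this read-out lower numbers stand for stronger inhibition and higher numbers for weaker inhibition), compound 1 gives > 100000 nM, and that value is a limit of the assay, not a number. Compound 3 likewise returns only a limit, > 100000 nM. Among the compounds with values here, compound 2 is the one member of the set with a measured number, 2990 nM. Compound 1 therefore stands at the weak end of what is shown, sitting at the limit of > 100000 nM in this assay, at which 2 of the 3 values shown sit. Within the data shown here, no two of the measured compounds differ in only one place, so no single step between them can be read off, and nothing here says how a change on the six-membered aromatic ring moves the read-out.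

The compound not yet measured is compound 4, `O=[N+]([O-])c1ccc(-c2nnc3nnc(N4CCCCC4)n3n2)cc1`. It differs from compound 1 by nitro in place of methoxy on an aromatic carbon. Nothing measured here tells how the nitro fares against the methoxy on this shared core. Because compound 1 sits at the limit of > 100000 nM in this assay, at which 2 of the 3 values shown sit, a step in this assay can only appear as a number if compound 4 reads stronger than that limit. Compound 4 is expected to give about 60000 nM, within 10000 nM to 300000 nM. The step that this estimate means, an at least 1.6-fold lower number from compound 1 to compound 4 (0.22 log units; that floor lies within the scatter), is expected to be small, and a second limit remains a real possibility.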

Compound 4, half-maximal inhibitory concentration: > 100000 nM
Compound 4 was reported as a limit; the forecaster's own chance of this, stated with the estimate: 55%; middle value at least 1.6-fold (0.22 log units) from the limit.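

In this assay compound 4 gives > 100000 nM as a limit of the assay and not a number. Compound 1 also returned only a limit, so no step can be read between compound 1 and compound 4: (the limit of > 100000 nM in this assay, at which 3 of the 4 values shown sit). The compounds shown leave open whether nitro or methoxy reads stronger on the shared core.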